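The source may hold more compounds than are shown below. What is called first, only, known or untested is meant among the compounds shown, and "the series" means these compounds.

Measured compounds:
- compound 1, `COc1ccc(-c2cn3ccnc3c(-c3ccc4ncn(C5CCCCC5)c4c3)n2)cc1`, gives 77.8% in a functional assay on SW-620 cells (Homo sapiens) for inhibition, read by sulforhodamine B assay, with a stated time of 48 h, tested at 10 uM; a higher number here means more inhibition at the concentration tested (going by the name of the read-out), a lower number less inhibition
- compound 2, `c1ccc2c(-c3cn4ccnc4c(-c4ccc5ncn(C6CCCCC6)c5c4)n3)cccc2c1`, gives 5.34% in this assay
- compound 3, `Fc1ccc(-c2cn3ccnc3c(-c3ccc4ncn(C5CCCCC5)c4c3)n2)cc1`, gives 8.38% in this assay

Compound 3 stands second highest of the three numbers, but its nearest neighbour, compound 2, lies within the scatter of it, as the step of a number 3 percentage points higher from compound 2 to compound 3 (within the scatter) shows; only compound 1 is clearly set apart, by the step of a number 69.4 percentage points lower from compound 1 to compound 3 (beyond the scatter). Compound 4, `Brc1ccc(-c2cn3ccnc3c(-c3ccc4ncn(C5CCCCC5)c4c3)n2)cc1`, differs from compound 3 in one place: bromo in place of fluoro on an aromatic carbon. Within the data shown here, no measured step swaps one halogen for another, so the bearing of the known steps is indirect. The step of a number 69.4 percentage points lower from compound 1 to compound 3 (beyond the scatter) shows that replacing methoxy with fluoro removes most of the inhibition, and the step of a number 72.5 percentage points lower from compound 1 to compound 2 (beyond the scatter) shows a comparable loss with naphthalen-1-yl. Nothing here shows that bromo would restore what methoxy gave, so a step in this assay of no more than the scatter is expected, in either direction. The expected step is a number 6.6 percentage points higher from compound 3 to compound 4 (within the scatter). Compound 4 is therefore estimated at 15%, within a range from 0% to 45%.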

Compound 4, a percentage reported as inhibition, at one concentration (the size of the read-out at that concentration, not a potency): 21.9%
Compound 4: the middle estimate sits 6.9 percentage points below what was measured, and the stated range covers the measured number.
By their numbers in this assay, from the lowest: compounds 2 and 3 (each within the scatter of the next); then compound 4; then compound 1.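

Swapping one halogen for another at this place, on an aromatic carbon para to a large group, is not neutral in this assay, as the step of a number 13.5 percentage points higher from compound 3 to compound 4 (beyond the scatter) shows, and the step of a number 16.6 percentage points higher from compound 2 to compound 4 (beyond the scatter) also sets the bromo compound apart from the naphthalen-1-yl compound. Even so, bromo recovers only part of what methoxy gave, as the step of a number 55.9 percentage points lower from compound 1 to compound 4 (beyond the scatter) makes clear, so moving from fluoro to bromo does not bring back the high inhibition of compound 1. No measurement at hand accounts for the gap between these groups.

Open, as far as these compounds go, is whether chloro or iodo would continue the change seen from fluoro to bromo. Also open, from the compounds shown here alone, is whether a hydroxy group, an ethoxy group or an amine at this place would come close to methoxy.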